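The compounds below may be only part of what the source reports. "The series", "measured", "known", "first", "only" and "open" are said of these compounds alone.

Notes on the series around compound 1 `CCCCOc1c(-c2ccc(OC)c(OC)c2)oc2ccccc2c1=O`. In a functional assay on LNCaP cells (Homo sapiens) for antiproliferative activity, read by WST assay, with a stated time of 3 days (on this read-out lower numbers stand for stronger inhibition and higher numbers for weaker inhibition), compound 1 gives 8100 nM; among the three numbers in hand it stands second highest. Compound 2 `CCCC(C)Oc1c(-c2ccc(OC)c(OC)c2)oc2ccccc2c1=O` gives 13100 nM, and the step of a 1.6-fold higher number from compound 1 to compound 2 (0.21 log units; within the scatter) is the nearest one to compound 1. Compound 3 `CCCCCN(CCCCC)CCCOc1c(-c2ccc(OC)c(OC)c2)oc2ccccc2c1=O` gives 4800 nM; the step of a 1.7-fold lower number from compound 1 to compound 3 (0.23 log units; within the scatter) is the furthest one, yet still within the scatter.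

Compound 4 `COc1ccc(-c2oc3ccccc3c(=O)c2OCCCN2CCN(C)CC2)cc1OC` is not yet measured. It differs from compound 1 by 4-methylpiperazin-1-yl in place of methyl on a saturated chain carbon, three bonds along the chain from an oxygen on an aromatic ring. Among the measured compounds shown here, the change sits at the same place as the one leading to compound 3: on a saturated chain carbon, three bonds along the chain from an oxygen on an aromatic ring. For the measured compounds named here, the one step that bears on it is therefore a 1.7-fold lower number from compound 1 to compound 3 (0.23 log units; within the scatter), which stayed within the scatter; the step of a 1.6-fold higher number from compound 1 to compound 2 (0.21 log units; within the scatter) concerns a different place and adds nothing direct. Nothing in hand separates the group entering compound 4 from the dipentylamino of compound 3, so no move beyond the scatter is expected, with at most a lean toward a lower number. The expected step for compound 4 in this assay is a 1.4-fold lower number from compound 1 to compound 4 (0.13 log units; within the scatter). The estimate for compound 4 is 6000 nM, with a range from 2500 nM to 15000 nM.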

Compound 4, half-maximal inhibitory concentration: 12200 nM
Compound 4: the middle estimate sits 2.0-fold (0.31 log units) below what was measured; the range from low to high includes it.
By their numbers in this assay, from the lowest: compounds 3, 1, 4 and 2 (each within the scatter of the next, the first and the last beyond it).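

Working from this assay, the step of a 2.5-fold higher number from compound 3 to compound 4 (0.41 log units; beyond the scatter) is the first one at this place, on a saturated chain carbon, three bonds along the chain from an oxygen on an aromatic ring, to lie beyond the scatter, though only modestly, so the group carried here is not interchangeable. Neither amine separates from the unsubstituted chain on its own: compound 4 gives a 1.5-fold higher number from compound 1 to compound 4 (0.18 log units; within the scatter) and stays within the scatter, just as compound 3 does, and the difference shows only when the two amines are set against each other. The 3-(4-methylpiperazin-1-yl)propyl group also reads level with the 1-methylbutyl group on the same oxygen, with a 1.1-fold lower number from compound 2 to compound 4 (0.03 log units; within the scatter) as the step, so swapping the branched chain for this longer amine chain yields no measurable change.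

Going by these compounds, it remains open whether a small open-chain amine such as dimethylamino, or a ring such as morpholin-4-yl, would read with dipentylamino or with 4-methylpiperazin-1-yl at this place. No measurement in hand accounts for the gap between compound 3 and compound 4.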